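Swapping the Methoxyphenyl Arm for a Pyridyl Arm

A few compounds are considered here, and "the series" means these few. Any claim that something is new, unique, unknown or untested is made for them only; others in the source may bear on it.

Of the compounds shown here, two share a core and have been tested in an assay on isolated protein for binding affinity to Adrenergic receptor alpha-1 (Rattus norvegicus), read by radioligand binding; on this read-out lower numbers stand for stronger inhibition and higher numbers for weaker inhibition. Compound 1, with the structure `COc1ccc2c(c1)C(CCCN1CCN(c3ccccc3OC)CC1)=CCC2`, gives 24.5 nM in this assay. Compound 2, with the structure `COc1ccccc1N1CCN(CC/C=C2\CCCc3ccccc32)CC1`, gives 3.6 nM in this assay. Of these two numbers, compound 1 carries the higher one, and the gap between the two lies beyond the usual scatter of repeated measurements, so compound 1 is the weaker binder of the pair.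

The next compound is compound 3, with the structure `COc1ccc2c(c1)C(CCCN1CCN(c3ccccn3)CC1)=CCC2`, which has not yet been measured in this assay. It differs from compound 1 in one place: pyridin-2-yl in place of 2-methoxyphenyl on an amine nitrogen in a ring. Within the data shown here, because no step between two measured compounds of this kind is available, the size of the effect cannot be read off from the data; it can only be estimated.

For compound 3 the expected step is a 2.9-fold higher number from compound 1 to compound 3 (0.46 log units; beyond the scatter), a move toward weaker binding that goes beyond the scatter. Compound 3 is therefore estimated to give 70 nM in this assay, with a plausible range from 20 nM to 250 nM.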

Compound 3, half-maximal inhibitory concentration: 152 nM
For compound 3 the middle estimate is 2.2-fold (0.34 log units) below the measured one; measured number inside the range.
By their numbers in this assay, from the lowest: compound 2; then compound 1; then compound 3.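

In this assay, swapping the arm on the amine nitrogen in a ring gives a 6.2-fold higher number from compound 1 to compound 3 (0.79 log units; beyond the scatter), with pyridin-2-yl in place of 2-methoxyphenyl, and the move is toward weaker binding. Among these compounds, this is the first measured step at this position, and it shows that binding on the core of compound 1 responds to which aromatic arm sits there, with 2-methoxyphenyl the better of these two groups. The two groups have the same counts of hydrogen-bond donors and acceptors, so those counts do not separate them, and nothing at hand explains the loss of binding.

The change replaces the carbon-only ring with a ring holding a nitrogen and also removes the methoxy group, so this single step cannot say which of the two differences matters more; a plain phenyl arm would help to separate them. On these data alone, it also remains open whether a pyrimidin-2-yl arm would follow pyridin-2-yl, and whether the same swap would cost as much on the core of compound 2.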